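Para Substitution on the Aryl Ring: Chloro for Hydrogen

The compounds below may be only part of what the source reports. "The series", "measured", "known", "first", "only" and "open" are said of these compounds alone.

Measured compounds in a functional assay on HT-29 cells (Homo sapiens) for cytotoxicity, read by MTT assay, with a stated time of 48 h; on this read-out lower numbers stand for stronger inhibition and higher numbers for weaker inhibition:
- Compound 1 `O=C1C[C@H](OCc2cn(-c3ccc([N+](=O)[O-])cc3)nn2)[C@H]2CO[C@@H]1O2` gives 18300 nM.
- Compound 2 `O=C1C[C@H](OCc2cn(-c3ccccc3)nn2)[C@H]2CO[C@@H]1O2` gives 13400 nM.
- Compound 3 `O=C1C[C@H](OCc2cc(-c3ccccc3)no2)[C@H]2CO[C@@H]1O2` gives 16900 nM.

All three compounds share the same core, and in this assay their numbers sit close together. Compound 3 stands second highest of the three, but its gap to compound 1 and its gap to compound 2 both lie within the scatter, so no order among them can be claimed.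

Compound 4 `O=C1C[C@H](OCc2cc(-c3ccc(Cl)cc3)no2)[C@H]2CO[C@@H]1O2` differs from compound 3 in one place: chloro in place of hydrogen on an aromatic carbon. The chloro group enters on an aromatic carbon of a six-membered aromatic ring of carbon only, para to a large group.

Among the compounds with values here, only one measured step speaks to this kind of change, the removal of a group from the same kind of aromatic ring: a 1.4-fold lower number from compound 1 to compound 2 (0.14 log units; within the scatter). That step stayed within the scatter. Within the data shown here, no step involving a chloro group is available, and the ring that carries the change in compound 3 is of a different kind from that in compounds 1 and 2. The expectation is therefore a step of no size beyond the scatter, in either direction, from compound 3 to compound 4: a 1.1-fold lower number from compound 3 to compound 4 (0.05 log units; within the scatter). Compound 4 is thus estimated at 15000 nM, with a plausible range from 6000 nM to 40000 nM.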

Compound 4, half-maximal inhibitory concentration: 14500 nM
Compound 4: middle estimate off by 1.0-fold (0.01 log units), on the high side, within the range that was stated.
By their numbers in this assay, from the lowest: compounds 2, 4, 3 and 1 (each within the scatter of the next).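

In this assay, phenyl to 4-chlorophenyl gives a 1.2-fold lower number from compound 3 to compound 4 (0.07 log units; within the scatter), so placing chloro on this aromatic carbon, para to a large group, produces no change that can be told apart from the scatter. Within the data shown here, this is the first measured step that adds a group to the aryl ring of compound 3, and the first to involve chloro, and it matches the earlier removal of nitro from the aryl ring of compound 1, which gave a 1.4-fold lower number from compound 1 to compound 2 (0.14 log units; within the scatter) and also stayed within the scatter. No data are at hand to explain why this step is so small, or to show what the chloro group does here.

The compounds shown leave open whether a different group at this place, such as an amine, a carboxylic acid or a methoxy group, would move the number beyond the scatter. They also leave open whether chloro would give a similarly small step on the aryl ring of compound 2, whose ring linking the aryl group to the shared core differs from that of compound 3.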